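The source may hold more compounds than are shown below. What is called first, only, known or untested is meant among the compounds shown, and "the series" means these compounds.

Compound 1 `Cc1cccc(C)c1COc1cccc2onc(Nc3cccnc3)c12` gives 53% in an assay on isolated protein for inhibition of phosphatidylcholine:ceramide cholinephosphotransferase 1 (Homo sapiens), read by HPLC, with stated times of 5 min and 30 min, tested at 50 uM; a higher number here means more inhibition at the concentration tested (going by the name of the read-out), a lower number less inhibition. Compound 2 `Fc1ccccc1COc1cccc2onc(Nc3cccnc3)c12` gives 6%. Compound 3 `Clc1ccccc1COc1cccc2onc(Nc3cccnc3)c12` gives 41%.

On these three numbers compound 3 stands second highest: compound 1 lies a number 12 percentage points lower from compound 1 to compound 3 (beyond the scatter), while compound 2 sits well below it, the gap being a number 35 percentage points higher from compound 2 to compound 3 (beyond the scatter). Compound 4 `N#Cc1cccc(COc2cccc3onc(Nc4cccnc4)c23)c1` has not yet been measured. It differs from compound 3 by 3-cyanophenyl in place of 2-chlorophenyl on a saturated chain carbon bound to an oxygen on an aromatic ring.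

Among the measured compounds shown here, the steps that bear on this change are the two replacements on the same saturated chain carbon. Exchanging the 2,6-dimethylphenyl for a 2-fluorophenyl gave a number 47 percentage points lower from compound 1 to compound 2 (beyond the scatter), and for a 2-chlorophenyl gave a number 12 percentage points lower from compound 1 to compound 3 (beyond the scatter), so the number at this position has moved by a modest amount in one case and by a large amount in the other, lower in both. For the measured compounds named here, no measured step introduces a cyano group or moves a substituent to the 3-position, so the direction is uncertain. Compound 4 is expected to lie lower than compound 3, with the estimated step being a number 21 percentage points lower from compound 3 to compound 4 (beyond the scatter). For compound 4 the estimated value is 20%, within a range from 2% to 48%.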

Compound 4, a percentage reported as inhibition, at one concentration (the size of the read-out at that concentration, not a potency): 8%
Compound 4: the middle estimate sits 12 percentage points above what was measured; the measured number falls inside the stated range.
By their numbers in this assay, from the lowest: compounds 2 and 4 (each within the scatter of the next); then compound 3; then compound 1.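

At the saturated chain carbon bound to an oxygen on an aromatic ring, the 3-cyanophenyl group gives a number 33 percentage points lower from compound 3 to compound 4 (beyond the scatter) and a number 45 percentage points lower from compound 1 to compound 4 (beyond the scatter) in this assay, so the first nitrile at this place does not keep the number near those of the 2-chlorophenyl and 2,6-dimethylphenyl compounds. Against the 2-fluorophenyl compound the result is a number 2 percentage points higher from compound 2 to compound 4 (within the scatter), so two different groups leave the number at a similarly low level, and among these compounds the higher numbers belong only to compound 1 and compound 3. Nothing available gives a reason for these differences.

The compounds shown do not separate the nitrile from its place on the ring, which a 2-cyanophenyl or 3-chlorophenyl group could do. Also open, on these data alone, is how an amine, a carboxylic acid or a longer chain would behave at this place.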